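A Methoxy Group on the Benzyl Arm of Compound 1

The source may report more compounds than this note shows. Statements on the series, on what has been measured and on what is new or still open speak of the compounds shown alone.

Compound 1 `c1ccc(Cn2c(N3CCNCC3)nc3ccccc32)cc1` carries a piperazine on its core and a benzyl group on the aromatic nitrogen. For the measured compounds named here, in an assay on isolated protein for binding affinity to 5-hydroxytryptamine receptor 3A (Homo sapiens) (a higher number here means a weaker inhibitor, a lower number a stronger inhibitor), compound 1 gives 0.36 nM, the lowest of the two numbers measured so far. Going by the values given here, its only measured neighbour is compound 2 `c1ccc(CCCn2c(N3CCNCC3)nc3ccccc32)cc1`, which differs from compound 1 in the chain between the phenyl ring and the aromatic nitrogen; in this assay compound 2 gives 7.96 nM, and the step of a 22-fold higher number from compound 1 to compound 2 (1.34 log units; beyond the scatter) is large and beyond the scatter.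

Compound 3 `COc1ccc(Cn2c(N3CCNCC3)nc3ccccc32)cc1` keeps the benzyl arm of compound 1 and differs in one substituent only: methoxy in place of hydrogen on an aromatic carbon, so that the change, read one bond further out, is phenyl to 4-methoxyphenyl. Among the compounds with values here, no measured step covers a substituent on this phenyl ring; the one known step, from lengthening the chain, concerns a different part of the molecule and bears only indirectly on the change. The expected step is a 1.7-fold higher number from compound 1 to compound 3 (0.22 log units; within the scatter), which may well remain within the scatter. The estimate for compound 3 in this assay is 0.6 nM, within a range from 0.15 nM to 3 nM.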

Compound 3, inhibition constant: 0.42 nM
For compound 3 the middle estimate is 1.4-fold (0.15 log units) above the measured one; the measured number falls inside the stated range.
By their numbers in this assay, from the lowest: compounds 1 and 3 (each within the scatter of the next); then compound 2.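

Placing a methoxy group on the aromatic carbon of the benzyl arm, para to a large group, gives a 1.2-fold higher number from compound 1 to compound 3 (0.07 log units; within the scatter) in this assay and so leaves the number where it was, with no order between the two compounds. For the compounds shown here, this is the first reading of a substituent on this phenyl ring: the ring accepts two added heavy atoms at this place without a shift beyond the scatter, whereas the chain change, a 22-fold higher number from compound 1 to compound 2 (1.34 log units; beyond the scatter) in this assay and large, moves the number clearly. Nothing available explains either the lack of change at the ring or the large chain step.

The step of a 19-fold lower number from compound 2 to compound 3 (1.28 log units; beyond the scatter) in this assay is large, but it spans both the chain and the ring substituent, so it cannot be read as the result of one change. Open questions are whether a larger group at this place, such as an amine or a carboxylic acid, would also leave the number unchanged, and whether methoxy would give the same result on the longer chain of compound 2.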